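The source may report more compounds than this note shows. Statements on the series, on what has been measured and on what is new or still open speak of the compounds shown alone.

Compound 1 `O=S(=O)(c1cccc(F)c1)c1cn(C2CCNC2)c2ncccc12` gives 2.7 nM in an assay on HeLa cells for displacement of a labelled ligand from 5-hydroxytryptamine receptor 6 (Homo sapiens); on this read-out higher numbers stand for weaker inhibition and lower numbers for stronger inhibition. Compound 2 `O=S(=O)(c1cccc(F)c1)c1cn(C2CCCNC2)c2ncccc12` gives 2.4 nM in this assay; the step of a 1.1-fold lower number from compound 1 to compound 2 (0.05 log units; within the scatter) lies within the scatter, so compound 2 stands alongside compound 1 rather than apart from it, and the two values cannot be told apart. Compound 3 `CN1CCCC(n2cc(S(=O)(=O)c3cccc(F)c3)c3cccnc32)C1` differs from compound 2 by methyl in place of hydrogen on an amine nitrogen in a ring. For the measured compounds named here, no measured step tests this kind of change, and the only measured step was small. Compound 3 is therefore expected to show no step beyond the scatter, a 1.3-fold higher number from compound 2 to compound 3 (0.10 log units; within the scatter). Compound 3 is estimated at 3 nM, with a range from 1 nM to 9 nM.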

Compound 3, inhibition constant: 4.7 nM
Compound 3: middle estimate off by 1.6-fold (0.19 log units), on the low side, and the stated range covers the measured number.
By their numbers in this assay, from the lowest: compounds 2, 1 and 3 (each within the scatter of the next).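

Methyl in place of hydrogen on the amine nitrogen in the ring, a change not tested by the earlier pair, gives a 2.0-fold higher number from compound 2 to compound 3 (0.29 log units; within the scatter) in this assay and so does not move the number beyond the scatter. Going from the smaller ring to 1-methylpiperidin-3-yl on the aromatic nitrogen gives a 1.7-fold higher number from compound 1 to compound 3 (0.24 log units; within the scatter) and likewise stays inside it. No supporting measurement accounts for this result. Still open, from the compounds shown here alone, is whether an ethyl, benzyl or acetyl group on this ring nitrogen would also leave the number within the scatter.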